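A few compounds are considered here, and "the series" means these few. Any claim that something is new, unique, unknown or untested is made for them only; others in the source may bear on it.

Measured compounds, all tested in a functional assay on PC-3 cells (Homo sapiens) for antiproliferative activity, read by WST assay, with a stated time of 3 days; a lower number here means a stronger inhibitor, a higher number a weaker inhibitor:

Compound 1 `CCCCOc1c(-c2cc(OC)c(OC)c(OC)c2)oc2ccccc2c1=O`: 12800 nM
Compound 2 `CCN(CC)CCCOc1c(-c2cc(OC)c(OC)c(OC)c2)oc2ccccc2c1=O`: 13600 nM
Compound 3 `CCCN(CCC)CCCCOc1c(-c2cc(OC)c(OC)c(OC)c2)oc2ccccc2c1=O`: 11600 nM

Compound 3 stands within the scatter of both other compounds, so these numbers do not rank the three. The next compound, compound 4 `CCCCCN(CCCCC)CCCOc1c(-c2cc(OC)c(OC)c(OC)c2)oc2ccccc2c1=O`, carries dipentylamino in place of (dipropylamino)methyl on a saturated chain carbon, three bonds along the chain from an oxygen on an aromatic ring.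

Among the measured compounds shown here, the closest precedent is the change at that same place, a 1.2-fold lower number from compound 2 to compound 3 (0.07 log units; within the scatter). The two steps that start from the side chain of compound 1 are similarly small: a 1.1-fold higher number from compound 1 to compound 2 (0.03 log units; within the scatter) and a 1.1-fold lower number from compound 1 to compound 3 (0.04 log units; within the scatter). All three lie within the scatter, so no step beyond the scatter is expected in this assay. For the measured compounds named here, no measured compound carries dipentylamino, however, so the range is kept wide and leans slightly towards lower numbers.

The expected change is a 1.2-fold lower number from compound 3 to compound 4 (0.06 log units; within the scatter). For compound 4 the estimated value is 10000 nM, with an expected range of 4500 nM to 20000 nM.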

Compound 4, half-maximal inhibitory concentration: 5800 nM
Compound 4: middle estimate off by 1.7-fold (0.24 log units), on the high side; measured number inside the range.
By their numbers in this assay, from the lowest: compounds 4, 3, 1 and 2 (each within the scatter of the next, the first and the last beyond it).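

In this assay, among the compounds shown here, dipentylamino gives the first steps that lie beyond the scatter: a 2.3-fold lower number from compound 2 to compound 4 (0.37 log units; beyond the scatter), where it replaces diethylamino, and a 2.2-fold lower number from compound 1 to compound 4 (0.34 log units; beyond the scatter), where it replaces methyl at the same place. Both steps are modest, and against the dipropylamino side chain the change stays inside the scatter, at a 2.0-fold lower number from compound 3 to compound 4 (0.30 log units; within the scatter), so compound 4 separates from compound 1 and compound 2 but not from compound 3. Nothing measured here explains this difference.

The compounds shown leave open whether a longer chain on the nitrogen, such as dihexylamino, would lower the number further. They also leave open how a cyclic amine such as piperidine or morpholine would compare with these open-chain amines.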